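The source may report more compounds than this note shows. Statements on the series, on what has been measured and on what is new or still open speak of the compounds shown alone.

Measured compounds:
- Compound 1 `Cc1nnc(SCC(=O)N/N=c2/scc(-c3ccc(F)cc3)n2-c2ccccc2)s1`: 26.5%
- Compound 2 `Cc1nnc(SCC(=O)N/N=c2/scc(-c3ccc(Cl)cc3)n2-c2ccccc2)s1`: 29%

In a functional assay on C6 cells (Rattus norvegicus) for cytotoxicity, read by MTT assay, with a stated time of 24 h, tested at 200 ug/mL (on this read-out lower numbers stand for a stronger effect and higher numbers for a weaker effect at the one concentration tested), compound 1 gives 26.5%, while compound 2 gives 29%. Among the compounds with values here, of the two numbers, compound 2 stands highest, but its only neighbour, compound 1, is separated from it by a number 2.5 percentage points higher from compound 1 to compound 2 (within the scatter), so the two cannot be told apart on this read-out.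

Compound 3 `O=C(CSc1nnnn1-c1ccccc1)N/N=c1/scc(-c2ccc(Cl)cc2)n1-c1ccccc1` has not yet been measured. It differs from compound 2 by 1-phenyl-1H-tetrazol-5-yl in place of 5-methyl-1,3,4-thiadiazol-2-yl on a sulfur. Within the data shown here, the single measured step, a number 2.5 percentage points higher from compound 1 to compound 2 (within the scatter), concerns a halogen on an aromatic carbon and says nothing about the group attached to the sulfur, so there is no measured step that bears directly on this change. Among the measured compounds shown here, the two known values are close together, and the only guide is that small changes elsewhere have left the read-out unmoved. The expected step is therefore a number 1 percentage points higher from compound 2 to compound 3 (within the scatter), with a wide uncertainty because the replaced part is larger than anything varied so far. Compound 3 is estimated to give 30% in this assay, within a range from 15% to 50%.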

Compound 3, a percentage reported as activity, at one concentration (the size of the read-out at that concentration, not a potency): 52.4%
For compound 3 the middle estimate is 22.4 percentage points below the measured one; measured number above the stated range.
By their numbers in this assay, from the lowest: compounds 1 and 2 (each within the scatter of the next); then compound 3.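

In this assay, replacing 5-methyl-1,3,4-thiadiazol-2-yl with 1-phenyl-1H-tetrazol-5-yl on the sulfur gives a number 23.4 percentage points higher from compound 2 to compound 3 (beyond the scatter) and so a weaker effect at the one concentration tested, whereas the halogen exchange gave a number 2.5 percentage points higher from compound 1 to compound 2 (within the scatter) and no change that can be told apart from scatter. The group on the sulfur is therefore the first place in this small series where the read-out clearly moves, although this one exchange alters several things at once: the entering group has more heavy atoms, a ring with four hetero atoms and an additional six-membered aromatic ring of carbon only. Nothing available here accounts for the shift.

The compounds shown leave open whether the larger number goes with the tetrazole ring itself or with the phenyl attached to it, a question that a compound carrying 1-methyl-1H-tetrazol-5-yl on the sulfur could help to separate. They also leave open whether the same exchange would produce a similar step with fluoro instead of chloro on the aromatic carbon.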